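Saturating the Side Chain of Compound 1

The compounds below may be only part of what the source reports. "The series", "measured", "known", "first", "only" and "open" are said of these compounds alone.

In a functional assay on A549 cells (Homo sapiens) for inhibition, read by sulforhodamine B assay, with a stated time of 72 h (on this read-out lower numbers stand for stronger inhibition of growth and higher numbers for weaker inhibition of growth), compound 1 (`CNC(=O)/C=C/c1ccncc1-c1ccc2ccccc2c1`) gives 6620 nM and holds the higher of the two true numbers. Compound 3 (`CCOC(=O)/C=C/c1ccncc1-c1ccc2c(ccn2C)c1`) gives 1720 nM as the nearest value, and that gap lies beyond the scatter. Compound 2 (`Cn1ncc2cc(-c3cnccc3/C=C/C(=O)O)ccc21`) reads > 10000 nM as a limit of the assay and not a number.

Compound 4 (`CNC(=O)CCc1ccncc1-c1ccc2ccccc2c1`) has not been measured. It keeps the core of compound 1 and carries 2-(methylcarbamoyl)ethyl in place of 2-(methylcarbamoyl)ethenyl on an aromatic carbon opposite the ring nitrogen. The side chain therefore loses its double bond and nothing else changes.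

Among the compounds with values here, no measured pair shows this change, so the expectation is a loose one. In this assay the expected result is a step within the scatter, leaning toward a higher number and so toward weaker inhibition of growth. The estimated move is a 1.4-fold higher number from compound 1 to compound 4 (0.13 log units; within the scatter) and no larger claim is made. Compound 4 is expected at 9000 nM (range 4000 nM to 20000 nM).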

Compound 4, concentration for 50% growth inhibition: 10400 nM
Compound 4: the middle estimate sits 1.2-fold (0.06 log units) below what was measured; the range from low to high includes it.
By their numbers in this assay, from the lowest: compound 3; then compounds 1 and 4 (each within the scatter of the next).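

Within the data shown here, this is the only pair here that differs in one place, so the double bond of the side chain can be judged on its own. In this assay, 2-(methylcarbamoyl)ethyl in place of 2-(methylcarbamoyl)ethenyl, opposite the ring nitrogen, gives a 1.6-fold higher number from compound 1 to compound 4 (0.20 log units; within the scatter), so these two compounds do not show that the double bond matters for growth inhibition. Any further weakening would be hard to follow, since compound 2 gives only a limit of the assay and not a number: the limit of > 10000 nM in this assay, at which 1 of the 4 values shown sits.

From the compounds shown here alone, it remains open whether an amine or a longer chain at this place would move the number beyond the scatter. Going by these compounds, it also remains open whether losing the double bond would give a similar step on the core of compound 3.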